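The source may report more compounds than this note shows. Statements on the series, on what has been measured and on what is new or still open speak of the compounds shown alone.

Measured so far:
compound 1, `Cc1cccc(NS(=O)(=O)c2ccc(N3CCNC3=O)cc2)c1`: 110 nM
compound 2, `O=C1NCCN1c1ccc(S(=O)(=O)Nc2ccc3c(c2)CCC3)cc1`: 190 nM

Both measured compounds share a core and differ only in the aryl group carried on the sulfonamide nitrogen. In a functional assay on HT-29 cells (Homo sapiens) for antiproliferative activity, read by sulforhodamine B assay, with a stated time of 48 h (a lower number here means a stronger inhibitor, a higher number a weaker inhibitor), compound 1 gives 110 nM, the lowest of the two numbers recorded. Compound 2, with its fused bicyclic aryl group, gives 190 nM in this assay; the gap between compound 1 and compound 2 lies within the usual scatter of repeated runs, so the two numbers cannot be ordered against each other.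

Compound 3, `Cc1ccc(C)c(NS(=O)(=O)c2ccc(N3CCNC3=O)cc2)c1`, has not yet been run in this assay. It is derived from compound 1 by a single change, (methyl in place of hydrogen on an aromatic carbon), placed on an aromatic carbon of the six-membered ring, ortho to a large group and para to the existing methyl group. Within the data shown here, no pair of measured compounds differs by this change, so there is no measured step to lean on. The two measured numbers sit close together, and a single added methyl is expected to move the number little: the step of a 1.4-fold higher number from compound 1 to compound 3 (0.13 log units; within the scatter) is expected to stay within the scatter, in either direction. Compound 3 is therefore estimated at 150 nM, with a range from 60 nM to 400 nM.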

Compound 3, half-maximal inhibitory concentration: 46 nM
Compound 3: the middle estimate sits 3.3-fold (0.51 log units) above what was measured; the measured number lies below the stated range.
By their numbers in this assay, from the lowest: compound 3; then compounds 1 and 2 (each within the scatter of the next).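

In this assay, among these compounds, the change from 3-methylphenyl to 2,5-dimethylphenyl on the sulfonamide nitrogen gives a 2.4-fold lower number from compound 1 to compound 3 (0.38 log units; beyond the scatter) and is the first step that lies beyond the scatter. The earlier compounds shown here gave no information on this aromatic carbon, ortho to a large group and para to the existing methyl group; the step shows that a methyl in place of hydrogen is accepted here and that it lowers the number, if modestly, rather than leaving it unchanged. Among the compounds shown here, nothing measured so far accounts for the size or direction of this step, which stands as an observation only.

As far as these compounds go, it remains open whether other groups on this carbon, such as an ethyl, a methoxy, a chlorine, an amine or a carboxylic acid, would lower the number further or reverse the step. From the compounds shown here alone, it is equally open whether the added methyl would give a similar step without the existing methyl group, or on the fused bicyclic aryl group of compound 2.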